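A Halogen Swap in a Level Permeability Series

A few compounds are considered here, and "the series" means these few. Any claim that something is new, unique, unknown or untested is made for them only; others in the source may bear on it.

In an ADME assay for permeability, using PAMPA, in phosphate buffer, with a stated time of 18 h, at pH 7.4 (a higher number here means that the compound crosses the layer faster, a lower number that the compound crosses the layer more slowly), compound 1 `Nc1ccc2oc(N3CCN(c4ccccc4)CC3)nc2c1` gives 10.3 10^-6 cm/s, compound 2 `Nc1ccc2oc(N3CCN(c4ccc(Cl)cc4)CC3)nc2c1` gives 10.6 10^-6 cm/s and compound 3 `Nc1ccc2oc(N3CCN(c4ccc(Br)cc4)CC3)nc2c1` gives 10.5 10^-6 cm/s. Compound 3 thus stands level with the other two, and the data set no order among the three. Compound 4 `Nc1ccc2oc(N3CCN(c4ccc(F)cc4)CC3)nc2c1` differs from compound 3 by fluoro in place of bromo on an aromatic carbon, para to a large group. Three measured steps at this same place bear on the change: a 1.0-fold higher number from compound 1 to compound 2 (0.01 log units; within the scatter), a 1.0-fold higher number from compound 1 to compound 3 (0.01 log units; within the scatter) and a 1.0-fold lower number from compound 2 to compound 3 (0.00 log units; within the scatter). Hydrogen, chloro and bromo there therefore read alike, although no fluoro compound has yet been measured. On that basis, no step beyond the scatter is expected in this assay, in either direction. The expected step is a 1.0-fold lower number from compound 3 to compound 4 (0.00 log units; within the scatter). Compound 4 is estimated at 10.4 10^-6 cm/s, with an expected range from 7 10^-6 cm/s to 15 10^-6 cm/s.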

Compound 4, apparent permeability: 10.7 10^-6 cm/s
The estimate for compound 4 lay 1.0-fold (0.01 log units) below the measured number; the measured number falls inside the stated range.
By their numbers in this assay, from the lowest: compounds 1, 3, 2 and 4 (each within the scatter of the next).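

In this assay, fluoro now joins the comparison at this place, with a 1.0-fold higher number from compound 3 to compound 4 (0.01 log units; within the scatter), a 1.0-fold higher number from compound 2 to compound 4 (0.00 log units; within the scatter) and a 1.0-fold higher number from compound 1 to compound 4 (0.02 log units; within the scatter). Hydrogen and all three halogens shown therefore read alike on an aromatic carbon, para to a large group, and no pair among these four compounds departs from the scatter. No measurement shown accounts for this sameness.

The compounds leave open whether the level reading would hold for a group of another kind at this place, such as an amine, a carboxylic acid or a longer chain. They also leave open whether fluoro in place of bromo would read the same at another place on the molecule or on a different core.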